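The source may hold more compounds than are shown below. What is called first, only, known or untested is meant among the compounds shown, and "the series" means these compounds.

Measured so far:
- compound 1 `COc1cc2c(cc1OC)C(CC(=O)O)CC2`: 18.8%
- compound 2 `COc1cc2c(cc1OC)C(CC(=O)Nc1ccc(Br)cc1)CC2`: 50%
- compound 3 `COc1cc2c(cc1OC)C(CC(=O)Nc1ccc([N+](=O)[O-])cc1)CC2`: 37.5%

All three share one core and were tested in a functional assay on the whole organism (strain Wistar) for inhibition, with Rattus norvegicus as the target, read by paw edema, with a stated time of 1 h, at a dose of 100 mg/kg; a lower number here means less inhibition, a higher number more inhibition at the dose given (going by the name of the read-out). Compound 2 gives the highest of the three numbers: compound 3 stands closest, and compound 1 stands furthest away. The two measured steps show what the amide end of the molecule does. Going from the free acid to the anilide, a number 31.2 percentage points higher from compound 1 to compound 2 (beyond the scatter). Swapping one substituent on that aromatic ring for another, a number 12.5 percentage points lower from compound 2 to compound 3 (beyond the scatter).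

Compound 4 `COc1cc2c(cc1OC)C(CC(=O)Nc1cccnc1)CC2` differs from compound 2 in one place: pyridin-3-yl in place of 4-bromophenyl on an amide-type nitrogen. The ring on the amide nitrogen is kept, but it now carries one hetero atom and has lost the bromine. Of the measured steps, the step from compound 2 to compound 3 bears most directly on this, since it also alters that ring while keeping the amide; the step from compound 1 to compound 2 shows how much the whole amide contributes. A modest drop is therefore expected rather than a large one: compound 4 is estimated at 38%, between 22% and 55%, meaning an expected step of a number 12 percentage points lower from compound 2 to compound 4 (beyond the scatter).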

Compound 4, a percentage reported as inhibition, in the whole organism at one dose (the size of the read-out at that dose, not a potency): 25%
Estimate against measurement, compound 4: 13 percentage points above; the measured number falls inside the stated range.
By their numbers in this assay, from the lowest: compounds 1 and 4 (each within the scatter of the next); then compound 3; then compound 2.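

In this assay, putting pyridin-3-yl in place of 4-bromophenyl on the amide-type nitrogen gives a number 25 percentage points lower from compound 2 to compound 4 (beyond the scatter), so the high number of compound 2 depends on the ring carried by that nitrogen and not just on the amide being there. The comparison with the free acid gives a number 6.2 percentage points higher from compound 1 to compound 4 (within the scatter) and so stays within the scatter, which means that an amide with a pyridin-3-yl ring shows no gain over the acid in this test. Nothing available explains why this ring change lowers the number

.

This change adds a ring nitrogen and removes the bromine at once, so the compounds shown leave open which of the two matters. A plain phenyl group on the amide nitrogen would help to separate these two changes.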